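Replacing an Amino Link by a Direct Aryl Bond

A few compounds are considered here, and "the series" means these few. Any claim that something is new, unique, unknown or untested is made for them only; others in the source may bear on it.

Of the compounds shown here, three have been measured in a functional assay on NCI/ADR-RES cells (Homo sapiens) for inhibition, read by sulforhodamine B assay, with a stated time of 48 h, tested at 1 uM; on this read-out lower numbers stand for a stronger effect and higher numbers for a weaker effect at the one concentration tested.
Compound 1 `COc1cc(Cl)cc(-c2nn(-c3cccc(NC(=O)Nc4ccc(Cl)c(C(F)(F)F)c4)c3)cc2-c2ccncc2)c1` gives 66%.
Compound 2 `COc1cc(Cl)cc(-c2nn(-c3cccc(NC(=O)Nc4ccc(Cl)c(Cl)c4)c3)cc2-c2ccncc2)c1` gives 78%.
Compound 3 `COc1cc(Cl)cc(-c2nn(-c3cccc(NC(=O)Nc4cccc(C(F)(F)F)c4)c3)cc2-c2ccncc2)c1` gives 65%.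

Compound 3 has the lowest number of the three. Its step to compound 1, a number 1 percentage points lower from compound 1 to compound 3 (within the scatter), lies within the scatter, so these two cannot be ranked against each other. Against compound 2 the step of a number 13 percentage points lower from compound 2 to compound 3 (beyond the scatter) is beyond the scatter, as is a number 12 percentage points higher from compound 1 to compound 2 (beyond the scatter).

Compound 4 `COc1cc(Cl)cc(-c2nn(-c3cccc(NC(=O)c4cccc(C(F)(F)F)c4)c3)cc2-c2ccncc2)c1` differs from compound 3 in one place: 3-(trifluoromethyl)phenyl in place of (3-(trifluoromethyl)phenyl)amino on a carbonyl carbon. All three measured steps exchange groups on the aromatic ring carried by the amide-type nitrogen; none alters the carbonyl carbon's other neighbour. Among the compounds with values here, no measured step therefore bears on this change, and the expectation rests on the assumption that removing the amino link costs a little. Compound 4 is expected to give 75%, in a range from 55% to 95%. For compound 4 this means an expected step of a number 10 percentage points higher from compound 3 to compound 4 (within the scatter), a modest weakening that may still fall within the scatter.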

Compound 4, a percentage reported as activity, at one concentration (the size of the read-out at that concentration, not a potency): 89%
Compound 4: middle estimate off by 14 percentage points, on the low side, and the stated range covers the measured number.
By their numbers in this assay, from the lowest: compounds 3 and 1 (each within the scatter of the next); then compound 2; then compound 4.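

In this assay, taking out the amino link so that the 3-(trifluoromethyl)phenyl ring sits directly on the carbonyl carbon gives a number 24 percentage points higher from compound 3 to compound 4 (beyond the scatter) and so a weaker effect, which shows that this link matters and not only the groups on the ring. The same kind of exchange, with a change of ring groups added, gives a number 23 percentage points higher from compound 1 to compound 4 (beyond the scatter) and a number 11 percentage points higher from compound 2 to compound 4 (beyond the scatter), leaving compound 4 with the highest number of the four, and the step from compound 3 is larger than any exchange of ring groups among compounds 1, 2 and 3. No measurement available here accounts for this weakening.

Still open, going by these compounds, is whether the amide hydrogen or the link itself counts, which a methylamino or methylene link on the same carbonyl carbon could separate. Also open, on these data alone, is whether a directly attached 3,4-dichlorophenyl ring behaves the same way.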